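Triazolylmethyl replaced by aminothiazolyl on the chain carbon

A few compounds are considered here, and "the series" means these few. Any claim that something is new, unique, unknown or untested is made for them only; others in the source may bear on it.

Compound 1 `CC(C)C(Cc1nnc[nH]1)c1ccc(-c2ccc3cccc(F)c3c2)[nH]c1=O` was tested in a functional assay on CHO cells for antagonist activity at prostaglandin E2 receptor EP3 subtype (Homo sapiens), read by cAMP accumulation (on this read-out lower numbers stand for stronger inhibition and higher numbers for weaker inhibition), where compound 1 gives 17 nM. That is the lowest number among the three compounds measured in this assay. Compound 2 `CCn1ncc2c(F)cc(-c3ccc(C(CC)(CC)c4nnc(C)[nH]4)c(=O)[nH]3)cc21` gives 90 nM, and compound 3 `CCn1ncc2c(F)cc(-c3ccc(C(CC)(CC)c4nncn4C)c(=O)[nH]3)cc21` gives 120 nM. Going by the values given here, the only step between two measured compounds that differ in one place is a 1.3-fold higher number from compound 2 to compound 3 (0.12 log units; within the scatter), a swap of the methyl within the same triazole that does not set the two apart. The gaps from compound 1 to compound 2 and to compound 3 lie beyond the scatter, but those compounds differ from compound 1 in more than one place, so they do not isolate a single change.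

Compound 4 `CC(C)C(c1cnc(N)s1)c1ccc(-c2ccc3cccc(F)c3c2)[nH]c1=O` differs from compound 1 by 2-amino-1,3-thiazol-5-yl in place of (4H-1,2,4-triazol-3-yl)methyl on a saturated chain carbon bound to an aromatic carbon and a saturated chain carbon. Among the compounds with values here, no measured step bears on this change: the one step available moves a methyl within a triazole and stays within the scatter, and nothing measured exchanges the triazole for another ring or alters how the ring joins the chain carbon. The expectation therefore rests on compound 1 alone and carries wide uncertainty; some weakening is expected rather than none, since the ring is changed outright. Compound 4 is estimated at 60 nM, with a range of 15 nM to 250 nM. This corresponds to an expected step of a 3.5-fold higher number from compound 1 to compound 4 (0.55 log units; beyond the scatter).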

Compound 4, half-maximal inhibitory concentration: 39 nM
Beside the measured number, compound 4's estimate is 1.5-fold (0.19 log units) above it; the range from low to high includes it.
By their numbers in this assay, from the lowest: compound 1; then compound 4; then compounds 2 and 3 (each within the scatter of the next).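

In this assay, setting 2-amino-1,3-thiazol-5-yl in place of (4H-1,2,4-triazol-3-yl)methyl on the saturated chain carbon gives a 2.3-fold higher number from compound 1 to compound 4 (0.36 log units; beyond the scatter), a modest loss that still lies beyond the scatter. Going by these compounds alone, the earlier compounds all carry a 1,2,4-triazole at this place, so this is the first sign that a different five-membered aromatic ring, with a different link to the chain carbon, can stand here and keep inhibition with only that modest change. No measured evidence accounts for this step.

Within the data shown here, the single exchange alters the ring and its link together, so it remains open which of them goes with the step; 4H-1,2,4-triazol-3-yl set directly on the chain carbon, or (2-amino-1,3-thiazol-5-yl)methyl, would separate the two. Also open, on these data alone, is what the amine on the thiazole contributes, which a plain 1,3-thiazol-5-yl or an acetamide in place of that amine would address.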